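The compounds below may be only part of what the source reports. "The series", "measured", "known", "first", "only" and "open" are said of these compounds alone.

Compound 1 `Cc1cccc(CCC(=O)N2CCN(c3ccc(C(F)(F)F)cc3[C@@H](N)CC(C)C)CC2)c1`: 2100 nM in an assay on HEK293 cells for displacement of a labelled ligand from Melanocortin receptor 4 (Homo sapiens); on this read-out lower numbers stand for stronger inhibition and higher numbers for weaker inhibition. Compound 2 `COc1cccc(CCC(=O)N2CCN(c3ccc(C(F)(F)F)cc3[C@@H](N)CC(C)C)CC2)c1`: 4000 nM. Compound 3 `CC(C)C[C@H](N)c1cc(C(F)(F)F)ccc1N1CCN(C(=O)CCc2ccc(S(C)(=O)=O)cc2)CC1`: 4900 nM.

Compound 3 stands at the highest number of the three: a 1.2-fold higher number from compound 2 to compound 3 (0.09 log units; within the scatter) leaves it level with compound 2, while a 2.3-fold higher number from compound 1 to compound 3 (0.37 log units; beyond the scatter) sets it apart from compound 1 by a modest margin.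

Compound 4 `COc1ccc(OC)c(CCC(=O)N2CCN(c3ccc(C(F)(F)F)cc3[C@@H](N)CC(C)C)CC2)c1` differs from compound 3 by 2,5-dimethoxyphenyl in place of 4-(methylsulfonyl)phenyl on a saturated chain carbon, two bonds along the chain from a carbonyl carbon. Two earlier steps touch the same position: a 2.3-fold higher number from compound 1 to compound 3 (0.37 log units; beyond the scatter) and a 1.2-fold higher number from compound 2 to compound 3 (0.09 log units; within the scatter), and a 1.9-fold higher number from compound 1 to compound 2 (0.28 log units; within the scatter) shows that a methoxy on that ring costs little against a methyl. Reversing the change toward a methoxy-bearing ring is therefore expected to give at most a small step in this assay, likely toward a lower number, a 1.4-fold lower number from compound 3 to compound 4 (0.15 log units; within the scatter). Compound 4 is estimated at 3500 nM (range 1500 nM to 8000 nM).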

Compound 4, inhibition constant: 2500 nM
For compound 4 the middle estimate is 1.4-fold (0.15 log units) above the measured one, and the stated range covers the measured number.
By their numbers in this assay, from the lowest: compounds 1, 4, 2 and 3 (each within the scatter of the next, the first and the last beyond it).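

In this assay, 2,5-dimethoxyphenyl on this saturated chain carbon gives no separation from the other aryl groups: a 2.0-fold lower number from compound 3 to compound 4 (0.29 log units; within the scatter) and a 1.6-fold lower number from compound 2 to compound 4 (0.20 log units; within the scatter) and a 1.2-fold higher number from compound 1 to compound 4 (0.08 log units; within the scatter) all stay within the scatter. The added methoxy and the exchange of 4-(methylsulfonyl)phenyl for 2,5-dimethoxyphenyl therefore both leave the read-out flat in this small set. No available evidence accounts for this flat response.

On these data alone, whether a carboxylic acid or an amine on the aryl ring, or a longer chain in place of the present one, would move the number beyond the scatter stays open.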